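The source may hold more compounds than are shown below. What is called first, only, known or untested is meant among the compounds shown, and "the series" means these compounds.

Compound 1 (`CCCOc1ccccc1C1CC(=O)c2ccccc2O1`), compound 2 (`CCCCCOc1ccccc1C1CC(=O)c2ccccc2O1`) and compound 3 (`O=C1CC(c2ccccc2OCc2ccccc2)Oc2ccccc21`) share one core and differ only in the group carried on an oxygen on an aromatic ring. In a functional assay on J774.A1 cells (Mus musculus) for inhibition, read by Griess assay, with stated times of 1 h and 24 h (on this read-out higher numbers stand for weaker inhibition and lower numbers for stronger inhibition), compound 1 gives 44600 nM, compound 2 gives 39300 nM and compound 3 gives 23200 nM. Compound 3 therefore stands within the scatter of both others, and no order can be drawn among the three. The steps that reach it are a 1.9-fold lower number from compound 1 to compound 3 (0.28 log units; within the scatter) and a 1.7-fold lower number from compound 2 to compound 3 (0.23 log units; within the scatter), and the remaining step is a 1.1-fold lower number from compound 1 to compound 2 (0.05 log units; within the scatter). Across these three compounds, exchanging the group on that oxygen has not moved the number beyond the scatter.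

Compound 4 (`O=C1CC(c2ccccc2O)Oc2ccccc21`) comes from compound 3 by one change, hydrogen in place of benzyl on an oxygen on an aromatic ring. Among the compounds with values here, this is benzyloxy to hydroxy, and no measured compound carries the hydroxy, so the three steps bear on it only indirectly. On that limited evidence, no step beyond the scatter is expected in this assay, in either direction. The expected step is a 1.3-fold higher number from compound 3 to compound 4 (0.11 log units; within the scatter). For compound 4 the estimate is 30000 nM, with an expected range from 11000 nM to 80000 nM.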

Compound 4, half-maximal inhibitory concentration: 71300 nM
Estimate against measurement, compound 4: 2.4-fold (0.38 log units) below; the measured number falls inside the stated range.
By their numbers in this assay, from the lowest: compounds 3, 2, 1 and 4 (each within the scatter of the next, the first and the last beyond it).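

Within the data shown here, replacing the group on the oxygen on the aromatic ring gives the first step at this position that clears the scatter in this assay: hydrogen in place of benzyl gives a 3.1-fold higher number from compound 3 to compound 4 (0.49 log units; beyond the scatter) and so a modest loss of inhibition, whereas exchanges among the propyl, pentyl and benzyl groups stayed within the scatter. The loss is confined to that one pair, since hydrogen in place of pentyl gives a 1.8-fold higher number from compound 2 to compound 4 (0.26 log units; within the scatter) and hydrogen in place of propyl gives a 1.6-fold higher number from compound 1 to compound 4 (0.20 log units; within the scatter) and both steps lie within the scatter, so compounds 1 and 2 go against any general rule that removing the group from this oxygen weakens inhibition. Nothing available explains the step from benzyl to hydrogen.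

From the compounds shown here alone, it remains open whether a shorter chain such as methyl, or a longer chain such as octyl, on this oxygen would stand apart from the hydroxy as benzyl does. Also open, going by these compounds, is how a benzyl carrying a fluorine or a methoxy group on its ring, or a chain ending in an amine or a carboxylic acid, would read in this assay.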